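The source may hold more compounds than are shown below. What is called first, only, known or untested is meant among the compounds shown, and "the series" means these compounds.

Compound 1, whose structure is `CCCCOC(=O)/C=C(C)/C=C/CC(C)CCCC(C)(C)OC`, is the more lipophilic of the two compounds measured in a physicochemical assay for lipophilicity; a higher number here means a more lipophilic compound, a lower number a more polar compound: compound 1 gives 6.62. Compound 2, with the structure `CCOC(=O)/C=C(C)/C=C/CC(C)CCCC(C)(C)OCC`, gives 6.08 in this assay; the gap between the two values lies beyond the scatter, so compound 1 stands at the top of the short series.

Compound 3, whose structure is `COC(C)(C)CCCC(C)C/C=C/C(C)=C/C(=O)N(C)C`, has not yet been measured. It differs from compound 1 in one place: dimethylamino in place of butoxy on a carbonyl carbon. The change strips away the butoxy group and puts a dimethylamino group on the same carbonyl carbon, turning the butoxycarbonyl end into a dimethylcarbamoyl end.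

Among the measured compounds shown here, no measured pair in this set shows such a change, so the size of the step can only be estimated. Given that compound 1 sits at 6.62 and that the group leaving is larger than the group entering, the expected step in this assay from compound 1 to compound 3 is a number 2.32 log units lower from compound 1 to compound 3 (beyond the scatter), a drop well beyond the scatter. Compound 3 is accordingly expected to give 4.3, within a range of 3.6 to 5.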

Compound 3, partition coefficient: 3.74
The estimate for compound 3 lay 0.56 log units above the measured number; measured number inside the range.
By their numbers in this assay, from the lowest: compound 3; then compound 2; then compound 1.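

In this assay, dimethylamino in place of butoxy on a carbonyl carbon gives a number 2.88 log units lower from compound 1 to compound 3 (beyond the scatter) and is a large step for a change at a single place, with the rest of the structure shared by the two compounds. Both earlier compounds carry an oxygen-linked chain on this carbonyl carbon, so they could not show what a nitrogen-linked group does there; this pair shows that the read-out responds strongly to the swap from butoxycarbonyl to dimethylcarbamoyl. No measurement in hand offers an explanation for the size of this step.

Among the compounds shown here, the single pair also leaves open how much of the step goes with the change from oxygen to nitrogen on the carbonyl carbon and how much with the change in size, from 5 heavy atoms in butoxy to 3 in dimethylamino. A dibutylamino group or a butylamino group on the same carbonyl carbon would help to separate the two, and a carboxylic acid or a pyrrolidine amide there would show how far the effect extends beyond this one pair.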